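This account rests on a few compounds, and the source may have more. Where it says the series, first, only, none or still open, it means among the compounds named here.

Compound 1 `COc1ccc([S+]([O-])c2cn(-c3ccc4c(c3)B(O)OC4)c3ccccc23)cc1` in an ADME assay on L929 cells (Mus musculus) for cytotoxicity, read by resazurin assay, with a stated time of 72 h (a lower number here means a stronger inhibitor, a higher number a weaker inhibitor), gave only a limit, > 10 ug/mL.
Compound 2 `Cc1ccc(C(=O)c2ccn(-c3ccc4c(c3)B(O)OC4)c2)cc1` in this assay likewise gave only a limit, > 10 ug/mL.
Compound 3 `Cc1ccccc1C(=O)c1ccn(-c2ccc3c(c2)B(O)OC3)c1` in this assay also gave only a limit, > 10 ug/mL.

All three measured compounds therefore sit at the same point, (the limit of > 10 ug/mL in this assay, at which 3 of the 3 values shown sit), and none of them shows a true number. Compound 3 cannot be placed above or below compound 1 or compound 2 on these data; it stands at a limit, nothing more. Within the data shown here, the single step measured between neighbours, a step that the two limits leave unreadable from compound 2 to compound 3, is unreadable for the same reason, as both of its ends are limits.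

Compound 4 `NCc1ccc(C(=O)c2ccn(-c3ccc4c(c3)B(O)OC4)c2)cc1` differs from compound 3 in one place: 4-(aminomethyl)phenyl in place of 2-methylphenyl on a carbonyl carbon. Among the measured compounds shown here, no measured step bears directly on this change, and the one step that exists gives no size. For the measured compounds named here, the only guide is that every compound of this series so far has stayed at the limit in this assay, so a weak effect is the most likely outcome again.

Compound 4 is therefore expected to give about 20 ug/mL in this assay, with a plausible range from 8 ug/mL to 60 ug/mL. The step that the limit leaves unreadable from compound 3 to compound 4 is expected to stay within the usual scatter, and most likely the result will again be reported only as a limit.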

Compound 4, half-maximal inhibitory concentration: > 10 ug/mL
Compound 4: a limit, no number; the forecaster's own chance of this, stated with the estimate: 75%; the middle value is on the limit's open side.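

Compound 4 also gave only a limit in this assay, so neither the step from compound 3 to compound 4 nor the step from compound 2 to compound 4 can be read. All the compounds shown stand at one point: the limit of > 10 ug/mL in this assay, at which 4 of the 4 values shown sit. These compounds leave open what true value each would give, and whether swapping 2-methylphenyl for 4-(aminomethyl)phenyl changes that value at all.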